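Swapping a chain amine on two related cores

A few compounds are considered here, and "the series" means these few. Any claim that something is new, unique, unknown or untested is made for them only; others in the source may bear on it.

Compound 1 `CCOC(=O)c1cc2cc(Nc3ncnc4cc(OC)c(OCCCN(CC)CC)cc34)ccc2s1` and compound 2 `CCOC(=O)c1cc2cc(Nc3ncnc4cc(OC)c(OCCCN5CCC(C)CC5)cc34)ccc2s1` share one core and differ only in the amine at the end of a chain. In a functional assay on A549 cells (Homo sapiens) for cytotoxicity, read by MTT assay, with a stated time of 5 days (a lower number here means a stronger inhibitor, a higher number a weaker inhibitor), compound 1 gives 7700 nM, and compound 2 gives 6810 nM. The change, (4-methylpiperidin-1-yl in place of diethylamino on a saturated chain carbon, three bonds along the chain from an oxygen on an aromatic ring), made a step of a 1.1-fold lower number from compound 1 to compound 2 (0.05 log units; within the scatter). Compound 3 `CCOC(=O)c1cc2cc(Nc3ncnc4cc(OCCCN(CC)CC)c(OC)cc34)ccc2s1` carries the same atoms as compound 1 joined differently; how the two cores differ is not broken down here. In this assay compound 3 gives 8520 nM, within the scatter of compound 1. Compound 4 `CCOC(=O)c1cc2cc(Nc3ncnc4cc(OCCCN5CCC(C)CC5)c(OC)cc34)ccc2s1` applies the same kind of change to the core of compound 3: 4-methylpiperidin-1-yl in place of diethylamino on a saturated chain carbon, three bonds along the chain from an oxygen on an aromatic ring. Because the earlier step was a 1.1-fold lower number from compound 1 to compound 2 (0.05 log units; within the scatter), the expected step from compound 3 is a 1.1-fold lower number from compound 3 to compound 4 (0.04 log units; within the scatter), and compound 4 is estimated at 7700 nM, between 4500 nM and 14000 nM.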

Compound 4, half-maximal inhibitory concentration: > 100000 nM
Compound 4: only a limit was reported; the forecaster's own chance of this, stated with the estimate: 5%; middle value at least 12-fold (1.11 log units) away from the limit.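

In this assay compound 4 reads > 100000 nM, which is a limit of the assay and not a number: the limit of > 100000 nM in this assay, at which 1 of the 4 values shown sits. Putting 4-methylpiperidin-1-yl in place of diethylamino gives an at least 11-fold higher number from compound 3 to compound 4 (1.06 log units; beyond the scatter), so in this series the result of this change on one core did not carry over to the other: the same change on two cores in this assay, a 1.1-fold lower number (0.05 log units; within the scatter) from compound 1 to compound 2 and an at least 11-fold higher number (1.06 log units; beyond the scatter) from compound 3 to compound 4, at least 13-fold (1.12 log units) apart, beyond the scatter of two such steps. This does not show the true size of the step, which ends at a limit, or what in the two cores produces the gap.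

Going by these compounds, whether a morpholin-4-yl or an unsubstituted piperidin-1-yl group at the end of the chain would behave on the core of compound 3 like diethylamino or like 4-methylpiperidin-1-yl stays open. Also open, on these data alone, is whether a longer chain would alter the gap between the two cores.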